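The source may report more compounds than this note shows. Statements on the series, on what has been measured and on what is new or still open speak of the compounds shown alone.

Compound 1 `Cc1ccccc1-c1nnc(N(C)NC(C)C)s1`: 38 mg/kg
Compound 2 `Cc1ccccc1-c1nnc(NN(C)C(C)C)s1`: > 100 mg/kg

In a functional assay on the whole organism with Mus musculus as the target, with a stated time of 1 h (on this read-out higher numbers stand for an effect only at larger amounts of compound and lower numbers for an effect already at smaller amounts), compound 2 stands only at a limit of the assay, not at a measured dose (the limit of > 100 mg/kg in this assay, at which 1 of the 2 values shown sits). Compound 1 does give a number, 38 mg/kg. Among the measured compounds shown here, the one measured step, an at least 2.6-fold higher number from compound 1 to compound 2 (0.42 log units; beyond the scatter), exchanged one six-atom group for another of the same size on the same aromatic carbon.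

Compound 3 `Cc1ccccc1-c1nnc(N(C)N(C)C)s1` has not yet been measured. From compound 2 to compound 3 the change is: a group of 5 heavy atoms (3 carbon, 2 nitrogen; no ring) in place of a group of 6 heavy atoms (4 carbon, 2 nitrogen; no ring), on an aromatic carbon. For the measured compounds named here, the single measured step is a different exchange and gives no direct guide to this one; the starting point itself is a limit, so the step from compound 2 can only be guessed broadly. Given that, the expected step is an at least 1.6-fold lower number from compound 2 to compound 3 (0.22 log units; that floor lies within the scatter), in the direction of a smaller number. Compound 3 is therefore estimated at 60 mg/kg, with a range from 25 mg/kg to 150 mg/kg.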

Compound 3, dose for half-maximal effect: 68 mg/kg
Compound 3: the middle estimate sits 1.1-fold (0.05 log units) below what was measured; measured number inside the range.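

With dimethylamino in place of isopropylamino on a nitrogen on an aromatic ring, this assay gives a 1.8-fold higher number from compound 1 to compound 3 (0.25 log units; within the scatter), so this exchange leaves compound 1 and compound 3 indistinguishable, and the (dimethylamino)(methyl)amino group, with 0 hydrogen-bond donors, still yields a measured dose. The other new step, an at least 1.4-fold lower number from compound 2 to compound 3 (0.16 log units; that floor lies within the scatter), gives only a floor, so it does not establish a real difference between these two compounds. That step cannot be read more closely, as compound 2 gives a limit and not a number: the limit of > 100 mg/kg in this assay, at which 1 of the 3 values shown sits.

The compounds shown leave open whether the same position accepts a longer chain such as n-butyl on that nitrogen, or a cyclic amine such as piperidine. They also leave open how a primary amine at this aromatic carbon would read in this assay.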